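From compound 2 to compound 3: a carboxymethyl group leaves

The compounds below may be only part of what the source reports. "The series", "measured", "known", "first", "only" and "open" are said of these compounds alone.

Compound 1 `CO[C@H]1C[C@H](C)CC2=C(N3CCC3)C(=O)C=C(NC(=O)/C(C)=C/C=C\[C@H](OC)[C@@H](OC(N)=O)/C(C)=C/[C@H](C)/C1=N\O)C2=O`: 310 nM
Compound 2 `CO[C@H]1C[C@H](C)CC2=C(NCCN(C)C)C(=O)C=C(NC(=O)/C(C)=C/C=C\[C@H](OC)[C@@H](OC(N)=O)/C(C)=C/[C@H](C)/C1=N\OCC(=O)O)C2=O`: 2700 nM

Both compounds were tested in a functional assay on SK-BR-3 cells (Homo sapiens) for cytotoxicity, read by CellTiter-Glo, with a stated time of 72 h; a lower number here means a stronger inhibitor, a higher number a weaker inhibitor. Of the two numbers, compound 2 holds the higher one, at 2700 nM, and its gap to compound 1 lies beyond the usual scatter. That makes compound 2 the weaker inhibitor of the pair in this assay.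

Compound 3 `CO[C@H]1C[C@H](C)CC2=C(NCCN(C)C)C(=O)C=C(NC(=O)/C(C)=C/C=C\[C@H](OC)[C@@H](OC(N)=O)/C(C)=C/[C@H](C)/C1=N\O)C2=O` has not yet been measured. It differs from compound 2 in one place: hydrogen in place of carboxymethyl on an oxygen. Hydrogen stands in place of carboxymethyl on an oxygen whose other neighbour is a double-bonded nitrogen, which also reads as carboxymethoxy to hydroxy.

For the measured compounds named here, no pair of measured compounds shows this change alone, so the expectation is a loose one. A step to a lower number in this assay, beyond the scatter, is expected, bringing compound 3 towards compound 1 at 310 nM. The estimated step runs a 6.0-fold lower number from compound 2 to compound 3 (0.78 log units; beyond the scatter). For compound 3 the expected value is 450 nM, with an estimated range of 130 nM to 1500 nM.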

Compound 3, half-maximal inhibitory concentration: 95 nM
The estimate for compound 3 lay 4.7-fold (0.68 log units) above the measured number; measured number below the stated range.
By their numbers in this assay, from the lowest: compound 3; then compound 1; then compound 2.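

Compound 3 gives a direct reading of the oxygen whose other neighbour is a double-bonded nitrogen. With (2-(dimethylamino)ethyl)amino held constant, hydrogen in place of carboxymethyl there gives, in this assay, a 28-fold lower number from compound 2 to compound 3 (1.45 log units; beyond the scatter), a large step that the earlier pair, which differed in two places, could not isolate. The change on the double-bonded ring carbon can now be read alone as well: with the hydroxy group held constant, (2-(dimethylamino)ethyl)amino in place of azetidin-1-yl gives a 3.3-fold lower number from compound 1 to compound 3 (0.51 log units; beyond the scatter), a modest step, and no measurement at hand accounts for either change.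

The compounds shown leave open what other groups on that oxygen would do, such as a methyl group, a methyl ester of the carboxylic acid or a longer chain ending in an amine. They also leave open how carboxymethyl on the oxygen reads with azetidin-1-yl on the ring carbon, and where other amines at that carbon, such as pyrrolidine or morpholine, would fall relative to compound 1 and compound 3.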